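A few compounds are considered here, and "the series" means these few. Any claim that something is new, unique, unknown or untested is made for them only; others in the source may bear on it.

Measured in a toxicity assay on HUVEC cells (Homo sapiens) for cytotoxicity, read by MTT assay, with a stated time of 96 h; a lower number here means a stronger inhibitor, a higher number a weaker inhibitor:
- Compound 1 `O=C1NC(=O)/C(=C\c2ccc(OCC(=O)N3N=C(c4ccccc4)CC3c3ccccc3Cl)cc2)S1`: 2000 nM
- Compound 2 `O=C1NC(=O)/C(=C\c2ccc(OCC(=O)N3N=C(c4ccccc4)CC3c3ccc(C(F)(F)F)cc3)cc2)S1`: > 10000 nM (a limit)

Compound 2 has no exact number, because its > 10000 nM is a limit of the assay. Compound 3 `O=C1NC(=O)/C(=C\c2ccc(OCC(=O)N3N=C(c4ccccc4)CC3c3ccc(Cl)c(Cl)c3)cc2)S1` keeps the shared core but carries 3,4-dichlorophenyl in place of 4-(trifluoromethyl)phenyl on a saturated ring carbon. Among the compounds with values here, only one measured step bears on this change: an at least 5.0-fold higher number from compound 1 to compound 2 (0.69 log units; beyond the scatter). It exchanged 2-chlorophenyl for 4-(trifluoromethyl)phenyl on that same carbon. Within the data shown here, compound 3 now reverses the exchange in part, since it again has a chlorinated phenyl, although not the one in compound 1. A lower number in this assay is therefore expected, on the evidence of that single step, and a second result at the limit remains possible. The expected change is an at least 2.0-fold lower number from compound 2 to compound 3 (0.30 log units; that floor lies within the scatter). For compound 3 the estimated value is 5000 nM, with an expected range of 1500 nM to 16000 nM.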

Compound 3, half-maximal inhibitory concentration: > 10000 nM
Compound 3 gave a limit, no number; the forecaster's own chance of this, stated with the estimate: 35%; middle value at least 2.0-fold (0.30 log units) away from the limit.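

The change from 2-chlorophenyl to 3,4-dichlorophenyl on this saturated ring carbon gives an at least 5.0-fold higher number from compound 1 to compound 3 (0.69 log units; beyond the scatter) in this assay. So a chlorine on this phenyl ring is not enough by itself to give a readable value, and of the three groups shown at this carbon, only the 2-chlorophenyl of compound 1 does so. The step between compound 2 and compound 3 cannot be read, because both values are limits and not numbers: the limit of > 10000 nM in this assay, at which 2 of the 3 values shown sit.

On these data alone, how far compound 2 and compound 3 lie beyond that limit remains open, and so does whether they differ from each other at all. Also open, as far as these compounds go, is whether a phenyl ring carrying an amine or a carboxylic acid at this carbon would give a readable value.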